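The compounds below may be only part of what the source reports. "The series", "measured", "known", "first", "only" and "open" are said of these compounds alone.

Compound 1 `Nc1nc(N)c2c(-c3ccsc3)cn([C@@H]3O[C@H](CO)[C@@H](O)[C@H]3O)c2n1` in a functional assay on HeLa S3 cells (Homo sapiens) for antiproliferative activity, read by XTT assay, with a stated time of 72 h (a higher number here means a weaker inhibitor, a lower number a stronger inhibitor), gives > 20000 nM, which is a limit of the assay.
Compound 2 `COc1nc(N)nc2c1c(-c1ccsc1)cn2[C@@H]1O[C@H](CO)[C@@H](O)[C@H]1O` in this assay gives > 20000 nM, again a limit of the assay.

Compound 1 thus stands only at a limit. Among the compounds with values here, the one measured step, a step that the two limits leave unreadable from compound 1 to compound 2, stays unreadable because the limit of > 20000 nM in this assay, at which 2 of the 2 values shown sit, covers both of its ends. Compound 3 `Nc1nc(N)c2c(-c3ccco3)cn([C@@H]3O[C@H](CO)[C@@H](O)[C@H]3O)c2n1` differs from compound 1 by furan-2-yl in place of thiophen-3-yl on an aromatic carbon. No measured step concerns this change, and the series as shown offers no readable step at all, so no move beyond the scatter is expected; the step that the limit leaves unreadable from compound 1 to compound 3 is an estimate resting on limits alone. Compound 3 is expected at 30000 nM, range 8000 nM to 150000 nM, most probably reported as a limit once more.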

Compound 3, half-maximal inhibitory concentration: > 20000 nM
Compound 3 gave a limit, no number (the forecaster's own chance of this, stated with the estimate: 80%); the middle value lies beyond the limit too.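

Within the data shown here, no step from compound 1 to compound 3 can be read in this assay, as both values are limits of the assay: the limit of > 20000 nM in this assay, at which 3 of the 3 values shown sit.
As far as these compounds go, whether furan-2-yl and thiophen-3-yl differ in effect on the shared core remains open.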